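The compounds below may be only part of what the source reports. "The series", "measured", "known", "first", "only" and "open" are said of these compounds alone.

Compound 1, `C=CCOc1nc(N)nc2c1ncn2/C=C1/CC1(CO)CO`, in an ADME assay on HFF cells (Homo sapiens) for cytotoxicity, with a stated time of 8 days; a higher number here means that more compound is tolerated, a lower number that less compound is tolerated: > 300000 nM, a limit of the assay only.
Compound 2, `CCOc1nc(N)nc2c1ncn2/C=C1/CC1(CO)CO`, in this assay: > 300000 nM, again only a limit of the assay.
Compound 3, `CCCSc1nc(N)nc2c1ncn2/C=C1/CC1(CO)CO`, in this assay: > 300000 nM, likewise only a limit of the assay.

All three values sit at the limit of > 300000 nM in this assay, at which 3 of the 3 values shown sit, so none of the three is a number. The steps between them, a step that the two limits leave unreadable from compound 1 to compound 2, a step that the two limits leave unreadable from compound 1 to compound 3 and a step that the two limits leave unreadable from compound 2 to compound 3, are therefore unreadable in size and direction. Compound 2 thus stands exactly where compounds 1 and 3 stand: at the limit, with no readable separation from either.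

Compound 4, `CCCCCCOc1nc(N)nc2c1ncn2/C=C1/CC1(CO)CO`, is not yet measured in this assay. It differs from compound 2 by butyl in place of hydrogen on a saturated chain carbon, two bonds along the chain from an oxygen on an aromatic ring. Among the measured compounds shown here, the steps that bear on this change are the chain variations at the same aromatic oxygen, a step that the two limits leave unreadable from compound 1 to compound 2 and a step that the two limits leave unreadable from compound 2 to compound 3, and both are unreadable since each end sits at the limit of > 300000 nM in this assay, at which 3 of the 3 values shown sit. For the measured compounds named here, no measured step therefore gives a size or a direction for extending the chain further.

The expectation for the step from compound 2 to compound 4 is a number no higher from compound 2 to compound 4 (the limit leaves the size open), that is, no step beyond the scatter that the data could show. Compound 4 is accordingly estimated at 300000 nM, with a range from 100000 nM to 1000000 nM, and most likely again only a limit.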

Compound 4, half-maximal cytotoxic concentration: > 200000 nM
Compound 4 ended at the assay's limit; the forecaster's own chance of this, stated with the estimate: 70%; the middle value is on the limit's open side.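

Among the compounds shown here, compound 4 gives > 200000 nM in this assay, again only a limit of the assay, and no step between it and compound 1, compound 2 or compound 3 can be read in size or direction. The compounds shown leave open the concentration at which any of the four becomes cytotoxic, and whether hexyloxy in place of ethoxy changes it.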